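The compounds below may be only part of what the source reports. "The series", "measured", "known", "first", "only" and "open" are said of these compounds alone.

Of the compounds shown here, two of a shared core have been measured in a functional assay on MGC-803 cells (Homo sapiens) for inhibition, read by MTT assay, with a stated time of 72 h; on this read-out higher numbers stand for weaker inhibition and lower numbers for stronger inhibition. Compound 1, `Cc1cc(Nc2cc(-c3ccccc3)[nH]n2)n2nc(SCc3nc4ccccc4[nH]3)nc2n1`, gives 1790 nM in this assay. Compound 2, `Cc1cc(Nc2cc(-c3ccccc3)[nH]n2)n2nc(SCC3CCCCC3)nc2n1`, gives 12600 nM in this assay, and this is the highest of the two numbers, so compound 2 is the weaker of the two. For the measured compounds named here, the only step recorded between them is a 7.0-fold higher number from compound 1 to compound 2 (0.85 log units; beyond the scatter), which means that the exchange of an aromatic group for a saturated ring at that position weakened inhibition by a modest but clear amount.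

Compound 3, `COc1ccc(CSc2nc3nc(C)cc(Nc4cc(-c5ccccc5)[nH]n4)n3n2)cc1`, has not yet been measured in this assay. It differs from compound 2 in one place: 4-methoxyphenyl in place of cyclohexyl on a saturated chain carbon bound to a sulfur. Going by the values given here, the group that enters is again an aromatic ring, so the change runs in the opposite sense to the one recorded step. Because that step, a 7.0-fold higher number from compound 1 to compound 2 (0.85 log units; beyond the scatter), cost inhibition when the aromatic group was lost, the return of an aromatic ring is expected to recover some of it. The number for compound 3 in this assay is therefore estimated to come out lower than that of compound 2, by a step of about a 3.2-fold lower number from compound 2 to compound 3 (0.50 log units; beyond the scatter), giving an expected value near 4000 nM with a likely range from 1500 nM to 11000 nM.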

Compound 3, half-maximal inhibitory concentration: 3170 nM
Estimate against measurement, compound 3: 1.3-fold (0.10 log units) above, and the stated range covers the measured number.
By their numbers in this assay, from the lowest: compounds 1 and 3 (each within the scatter of the next); then compound 2.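

In this assay, putting 4-methoxyphenyl in place of cyclohexyl on a saturated chain carbon bound to a sulfur gives a 4.0-fold lower number from compound 2 to compound 3 (0.60 log units; beyond the scatter) and shows that the gain seen with 1H-benzimidazol-2-yl is not confined to that one group: among these compounds, both aromatic groups give lower numbers than cyclohexyl does. Replacing 1H-benzimidazol-2-yl with 4-methoxyphenyl gives a 1.8-fold higher number from compound 1 to compound 3 (0.25 log units; within the scatter) and, as this step lies within the usual scatter, the two groups cannot be told apart in this read-out even though they are quite different in structure. Nothing measured alongside these numbers explains why the two aromatic groups differ from cyclohexyl.

On these data alone, it remains open whether the aromatic ring alone accounts for the gap to cyclohexyl or whether the methoxy group also contributes, a question that a plain phenyl group in the same place could help to answer. As far as these compounds go, it is also open how far this position tolerates other kinds of group, such as an amine, a carboxylic acid or a longer chain carrying the same ring.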